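Cyclopropyl for phenoxy on the four-membered ring

The source may report more compounds than this note shows. Statements on the series, on what has been measured and on what is new or still open speak of the compounds shown alone.

Values in a functional assay on MCF7 cells (Homo sapiens) for inhibition, read by resazurin assay, with a stated time of 72 h (on this read-out lower numbers stand for stronger inhibition and higher numbers for weaker inhibition), are as follows.
- compound 1 (`COc1ccc(C2C(O)C(=O)N2c2cc(OC)c(OC)c(OC)c2)cc1`) gives 4 nM
- compound 2 (`CCOc1ccc(C2C(C3CC3)C(=O)N2c2cc(OC)c(OC)c(OC)c2)cc1`) gives 131 nM
- compound 3 (`COc1ccc(C2C(Oc3ccccc3)C(=O)N2c2cc(OC)c(OC)c(OC)c2)cc1`) gives 23 nM

Compound 3 stands in the middle of the three, with compound 2 higher and compound 1 lower, and both gaps lie beyond the scatter. The next compound is compound 4 (`COc1ccc(C2C(C3CC3)C(=O)N2c2cc(OC)c(OC)c(OC)c2)cc1`), which has cyclopropyl in place of phenoxy on a saturated ring carbon.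

Going by the values given here, only one measured step touches this ring carbon, and it is modest: a 5.8-fold higher number from compound 1 to compound 3 (0.76 log units; beyond the scatter) (beyond the scatter). It shows that the number in this assay moves with a change at this place, but it does not cover a carbon-linked group. Among the compounds with values here, compound 2 (131 nM) is the only measured compound with cyclopropyl here, and it carries ethoxy where compound 4 has methoxy. Within the data shown here, no measured step isolates that swap, so its value serves only as a loose guide on the higher side.

A modest move to a higher number is therefore expected (a 2.2-fold higher number from compound 3 to compound 4 (0.34 log units; beyond the scatter)). Compound 4 is estimated at 50 nM (expected range 12 nM to 180 nM).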

Compound 4, half-maximal inhibitory concentration: 120 nM
The estimate for compound 4 lay 2.4-fold (0.38 log units) below the measured number; the measured number falls inside the stated range.
By their numbers in this assay, from the lowest: compound 1; then compound 3; then compounds 4 and 2 (each within the scatter of the next).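

In this assay, this ring carbon now carries a carbon-linked group on the same core as the oxygen-linked ones, and that group gives the highest number of the three: a 5.2-fold higher number from compound 3 to compound 4 (0.72 log units; beyond the scatter), and a 30-fold higher number from compound 1 to compound 4 (1.48 log units; beyond the scatter). Heavy-atom count does not set the order, since cyclopropyl has fewer heavy atoms than phenoxy yet gives the higher number, so hydroxy, phenoxy and cyclopropyl cannot be ranked by size alone. The comparison with the ethoxy analogue adds a second point, a 1.1-fold lower number from compound 2 to compound 4 (0.04 log units; within the scatter), which places compound 2 and compound 4 within the scatter of each other and shows that, with cyclopropyl on the ring carbon, ethoxy and methoxy on the aromatic ring cannot be told apart. Nothing available explains these steps.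

With only one carbon-linked group and two oxygen-linked groups at this place, the compounds shown leave open whether the linking atom matters at all, or whether an amine or a longer alkyl chain here would fall nearer hydroxy or cyclopropyl. On these data alone, whether ethoxy and methoxy would also match with hydroxy or phenoxy on the ring carbon remains open too.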